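Working notes: double bond configuration, compound 3 to compound 4

The source may hold more compounds than are shown below. What is called first, only, known or untested is meant among the compounds shown, and "the series" means these compounds.

Measured in a functional assay on HL-60 cells (Homo sapiens) for cytotoxicity, read by WST assay, with a stated time of 48 h; on this read-out higher numbers stand for an effect only at larger amounts of compound and lower numbers for an effect already at smaller amounts:
- Compound 1 `COc1ccc(C[C@H]2C(=O)OC[C@@H]2Cc2ccccc2)cc1OC`: > 100000 nM (a limit)
- Compound 2 `Cc1ccc(C[C@H]2C(=O)OC[C@@H]2Cc2ccccc2)cc1C`: 35000 nM
- Compound 3 `CCCCOc1ccc(/C=C2\C(=O)OC[C@@H]2Cc2ccccc2)cc1`: 58000 nM

Compound 2 at 35000 nM and compound 3 at 58000 nM lie within the usual scatter of each other. Compound 1 gives only a limit, > 100000 nM, and no number.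

Compound 4 `CCCCOc1ccc(/C=C2/C(=O)OC[C@@H]2Cc2ccccc2)cc1` is the next case, set against compound 3: the two compounds have the same atoms and bonds and differ only in configuration as drawn: 1 of 2 stereo elements differ; a double bond is drawn Z in compound 3 and E in compound 4. The double bond is drawn Z in compound 3 and E in compound 4. Within the data shown here, no measured pair shows this change alone, so in this assay the expected size is a 1.3-fold lower number from compound 3 to compound 4 (0.11 log units; within the scatter), with no step beyond the scatter expected. The estimate rests on compound 3 at 58000 nM and is wide. For compound 4 the estimated value is 45000 nM, with an expected range from 14000 nM to 100000 nM.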

Compound 4, half-maximal effective concentration: > 100000 nM
Compound 4: only a limit was reported; the forecaster's own chance of this, stated with the estimate: 15%; at least 2.2-fold (0.34 log units) between middle value and limit.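

In this assay the step is an at least 1.7-fold higher number from compound 3 to compound 4 (0.23 log units; that floor lies within the scatter), the first in the series to isolate this double bond, and it can be read on configuration alone: the fact that compounds 3 and 4 differ only in the configuration as drawn
Compound 4 gives > 100000 nM, which is a limit and not a number.
The full size of the step therefore stays unresolved because of this limit: the limit of > 100000 nM in this assay, at which 2 of the 4 values shown sit.

The compounds shown leave open whether this change reads the same with a longer chain, an amine or a carboxylic acid in place of the ether chain. As far as these compounds go, the role of the other stereo element also stays open.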